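The source may report more compounds than this note shows. Statements on the series, on what has been measured and on what is new or still open speak of the compounds shown alone.

Of the compounds shown here, three carrying one shared core have been tested in a functional assay on MCF7 cells (Homo sapiens) for antiproliferative activity, read by CCK-8 assay, with a stated time of 72 h (on this read-out lower numbers stand for stronger inhibition and higher numbers for weaker inhibition), and all three differ only in the aromatic group attached to the carbonyl carbon of the amide. Compound 1 `O=C(Nc1cccc(-c2oc3cc(-c4ccc(F)cc4)ccc3c(=O)c2O)c1)c1ccc(Cl)cc1` gives 4730 nM. Compound 2 `O=C(Nc1cccc(-c2oc3cc(-c4ccc(F)cc4)ccc3c(=O)c2O)c1)c1ccc(C(F)(F)F)cc1` gives 32600 nM. Compound 3 `Cc1cc(C(=O)Nc2cccc(-c3oc4cc(-c5ccc(F)cc5)ccc4c(=O)c3O)c2)ccc1F` gives 7710 nM, which places it second highest of the three numbers: the step of a 1.6-fold higher number from compound 1 to compound 3 (0.21 log units; within the scatter) lies within the scatter, while the step of a 4.2-fold lower number from compound 2 to compound 3 (0.63 log units; beyond the scatter) lies beyond it.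

Compound 4 `Cc1cc(C)cc(C(=O)Nc2cccc(-c3oc4cc(-c5ccc(F)cc5)ccc4c(=O)c3O)c2)c1` is the next member of the series and has not yet been measured in this assay. Its change from compound 3 is 3,5-dimethylphenyl in place of 4-fluoro-3-methylphenyl on a carbonyl carbon. The two measured steps that bear on this change are the swaps of the group on the same carbonyl carbon, namely a 1.6-fold higher number from compound 1 to compound 3 (0.21 log units; within the scatter) and a 4.2-fold lower number from compound 2 to compound 3 (0.63 log units; beyond the scatter): one within the scatter, the other modest. Among these three compounds the exchange of one substituted phenyl for another on the carbonyl carbon has moved the number by at most a modest amount, so a step of similar or smaller size is expected for a 1.2-fold lower number from compound 3 to compound 4 (0.07 log units; within the scatter), in either direction.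

The number estimated for compound 4 in this assay is therefore 6500 nM, with an expected range from 2500 nM to 17000 nM.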

Compound 4, half-maximal inhibitory concentration: 20400 nM
For compound 4 the middle estimate is 3.1-fold (0.50 log units) below the measured one; measured number above the stated range.
By their numbers in this assay, from the lowest: compounds 1 and 3 (each within the scatter of the next); then compounds 4 and 2 (each within the scatter of the next).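

In this assay the exchange at the carbonyl carbon that keeps the heavy-atom count and replaces only fluorine with carbon still gives a modest change, a 2.6-fold higher number from compound 3 to compound 4 (0.42 log units; beyond the scatter), beyond the scatter, so even this small edit to the substituted phenyl is not silent. The new compound also sharpens the picture across the series: a 1.6-fold lower number from compound 2 to compound 4 (0.20 log units; within the scatter) stays within the scatter, whereas a 4.3-fold higher number from compound 1 to compound 4 (0.63 log units; beyond the scatter) lies beyond it, so the four compounds now form two groups, compounds 1 and 3 with the lower numbers and compounds 2 and 4 with the higher ones. No measurement available here accounts for this split.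

Compound 4 differs from compound 3 by a fluorine leaving and a second methyl entering, so a 3-methylphenyl group on the same carbonyl carbon would be needed to tell these two parts of the change apart. All the groups at this position are phenyl rings carrying halogen, methyl or trifluoromethyl substituents, which leaves open how an unsubstituted phenyl, or a phenyl bearing an amine or a carboxylic acid, would behave.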